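Bromine to fluorine on the aryl ring of compound 1

A few compounds are considered here, and "the series" means these few. Any claim that something is new, unique, unknown or untested is made for them only; others in the source may bear on it.

Compound 1 `CC(C)(C)n1ncc(OCc2nnc(-c3ccc(Br)cc3)o2)c(Cl)c1=O` is the starting point. In a functional assay on the whole organism for inhibition, with Mythimna separata as the target, with a stated time of 5 days (a higher number here means that more compound is needed for the effect, a lower number that less compound is needed), compound 1 gives 21400 nM. Compound 2 `CCn1ncc(OCc2nnc(-c3ccccc3)o2)c(Cl)c1=O` reaches only a limit of this assay, > 299000 nM. Compound 3 `Cc1cc(C)cc(-c2nnc(COc3cnn(C(C)(C)C)c(=O)c3Cl)s2)c1` likewise reaches only a limit, > 299000 nM. Among the compounds with values here, compound 1 therefore stands as the only genuine number among the three, the other two sitting at the limit of > 299000 nM in this assay, at which 2 of the 3 values shown sit.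

Compound 4 `CC(C)(C)n1ncc(OCc2nnc(-c3cccc(F)c3)o2)c(Cl)c1=O` differs from compound 1 by 3-fluorophenyl in place of 4-bromophenyl on an aromatic carbon. Within the data shown here, no measured pair isolates this change, so the expected step from compound 1 to compound 4 is estimated as a 2.8-fold higher number from compound 1 to compound 4 (0.45 log units; beyond the scatter), a loss somewhat beyond the scatter. Compound 4 is therefore expected to give about 60000 nM in this assay, with a likely range from 15000 nM to 299000 nM.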

Compound 4, half-maximal effective concentration: 7100 nM
Compound 4: middle estimate off by 8.5-fold (0.93 log units), on the high side; the measured number lies below the stated range.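

In this assay, 3-fluorophenyl in place of 4-bromophenyl on this aromatic carbon gives a 3.0-fold lower number from compound 1 to compound 4 (0.48 log units; beyond the scatter), a modest gain. The 4-bromophenyl group is therefore not required for a measurable value, and this place on the shared core accepts a different halogen-bearing phenyl. The change alters both the halogen and its place on the phenyl ring, and nothing shown here accounts for the step.

Which of those two alterations drives the step stays open. So does how a phenyl ring carrying a methoxy group or an amine would behave at this carbon.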